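A few compounds are considered here, and "the series" means these few. Any claim that something is new, unique, unknown or untested is made for them only; others in the source may bear on it.

Measured so far in a functional assay on HepG2 cells (Homo sapiens) for antiproliferative activity, read by MTT assay, with a stated time of 72 h; on this read-out lower numbers stand for stronger inhibition and higher numbers for weaker inhibition:
- compound 1 `O=C(N/N=C/c1ccc(Br)cc1)Nc1ccc(Oc2ccnc3[nH]ccc23)c(F)c1` gives 1000 nM
- compound 2 `O=C(N/N=C/c1ccc(Cl)c(Cl)c1)Nc1ccc(Oc2ccnc3[nH]ccc23)c(F)c1` gives 3700 nM
- compound 3 `COc1ccc(/C=N/NC(=O)Nc2ccc(Oc3ccnc4[nH]ccc34)c(F)c2)cc1` gives 1770 nM

Compound 3 stands at 1770 nM and is set apart from only one of the other two: a 2.1-fold lower number from compound 2 to compound 3 (0.32 log units; beyond the scatter), whereas a 1.8-fold higher number from compound 1 to compound 3 (0.25 log units; within the scatter).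

The next step leads to compound 4 `CN(C)CCn1cccc1/C=N/NC(=O)Nc1ccc(Oc2ccnc3[nH]ccc23)c(F)c1`, with 1-(2-(dimethylamino)ethyl)-1H-pyrrol-2-yl in place of 4-methoxyphenyl on a carbon with a double bond to nitrogen.

The steps bearing on this change are the swaps of the group at that same carbon. These are modest, with a 3.7-fold higher number from compound 1 to compound 2 (0.57 log units; beyond the scatter) and a 2.1-fold lower number from compound 2 to compound 3 (0.32 log units; beyond the scatter). All of them exchange one six-membered aromatic ring for another. Among the measured compounds shown here, no measured compound carries a five-membered aromatic ring or a dimethylamino chain there, so the new group is untested and any direction remains open. No step beyond the scatter is expected in this assay, though with low confidence. The expected move is a 1.4-fold lower number from compound 3 to compound 4 (0.13 log units; within the scatter). For compound 4 the estimated value is 1300 nM, with an expected range of 300 nM to 5000 nM.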

Compound 4, half-maximal inhibitory concentration: 8980 nM
Compound 4: middle estimate off by 6.9-fold (0.84 log units), on the low side; measured number above the stated range.
By their numbers in this assay, from the lowest: compounds 1 and 3 (each within the scatter of the next); then compound 2; then compound 4.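

In this assay this carbon tolerates less than the swaps among six-membered aromatic rings suggested: 1-(2-(dimethylamino)ethyl)-1H-pyrrol-2-yl gives (a 5.1-fold higher number from compound 3 to compound 4 (0.71 log units; beyond the scatter)) and (a 2.4-fold higher number from compound 2 to compound 4 (0.39 log units; beyond the scatter)) and (a 9.0-fold higher number from compound 1 to compound 4 (0.95 log units; beyond the scatter)). All three steps are beyond the scatter and point the same way, so compound 4 is the weakest of the four, and the first five-membered aromatic ring at this position brings no gain over any of the six-membered rings. Nothing on hand accounts for this drop.

The change replaces the ring and adds the chain in one step, so the share of each in the drop stays unresolved. An unsubstituted pyrrol-2-yl group and a phenyl ring carrying a dimethylaminoethyl chain would be the groups that separate the two.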